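Dinitrobenzyl thioether series: chloro to piperidin-1-yl

A few compounds are considered here, and "the series" means these few. Any claim that something is new, unique, unknown or untested is made for them only; others in the source may bear on it.

Values measured in an ADME assay on MRC5 cells (Homo sapiens) for cytotoxicity, read by neutral red uptake (on this read-out higher numbers stand for lower toxicity in this test and lower numbers for higher toxicity in this test), so far:
Compound 1 `N#Cc1c(-c2cccc(Br)c2)nc(SCc2ccccc2)[nH]c1=O` gives > 36000 nM
Compound 2 `O=c1[nH]c(SCc2cc([N+](=O)[O-])cc([N+](=O)[O-])c2)nc2ccc(Cl)cc12` gives > 64000 nM

Both entries are limits of the assay and not numbers. Going by the values given here, compound 2 stands only at the limit > 64000 nM and has no number in this assay so far. Compound 1 likewise reports the limit > 36000 nM and no number. The two compounds therefore cannot be ranked against each other.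

Compound 3 `O=c1[nH]c(SCc2cc([N+](=O)[O-])cc([N+](=O)[O-])c2)nc2ccc(N3CCCCC3)cc12` keeps the rest of compound 2 and carries piperidin-1-yl in place of chloro on an aromatic carbon, the position being para to a fused ring and meta to a fused ring [ piperidin-1-yl in place of chloro on an aromatic carbon ]. Among the compounds with values here, no measured pair shows what such a change does, so the expectation rests on the two limits alone. The step of an at least 1.4-fold lower number from compound 2 to compound 3 (0.15 log units; that floor lies within the scatter) is expected to stay within the usual scatter of this assay and no clear direction is expected. Compound 3 is estimated at 45000 nM with an expected range of 14000 nM to 110000 nM and a fair chance of only a limit again.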

Compound 3, half-maximal cytotoxic concentration: > 64000 nM
Compound 3 was reported as a limit; the forecaster's own chance of this, stated with the estimate: 55%; middle value at least 1.4-fold (0.15 log units) away from the limit.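

No step can be read from compound 2 to compound 3, because both entries in this assay are limits and not numbers: the limit of > 64000 nM in this assay, at which 2 of the 3 values shown sit.

What piperidin-1-yl in place of chloro on an aromatic carbon does in this assay stays open, since the compounds shown give no number on either side of this change.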